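The source may hold more compounds than are shown below. What is called first, only, known or untested is meant among the compounds shown, and "the series" means these compounds.

Measured compounds in an assay on isolated protein for inhibition of Indoleamine 2,3-dioxygenase 1 (Homo sapiens), with a stated time of 60 min, tested at 10 uM; a lower number here means less inhibition, a higher number more inhibition at the concentration tested (going by the name of the read-out):
compound 1 `Clc1ccc2[nH]c(SCc3ccccc3Oc3ccccc3)nc2c1` gives 30%
compound 2 `Clc1ccc2[nH]c(SCc3ccccc3/C=C\c3ccccc3)nc2c1` gives 49%
compound 3 `c1ccc(CCc2ccccc2CSC2=NCCN2)cc1` gives 17%

Compound 2 stands highest of the three numbers; the nearest is compound 1 and the furthest is compound 3, both gaps beyond the scatter. Compound 4 `Clc1ccc2[nH]c(SCc3ccccc3CCc3ccccc3)nc2c1` has not yet been measured in this assay. It differs from compound 2 in one place: phenethyl in place of 2-phenylethenyl on an aromatic carbon. For the measured compounds named here, one measured step touches the same position, a number 19 percentage points higher from compound 1 to compound 2 (beyond the scatter), a modest rise. Going by the values given here, no measured pair sets phenethyl against 2-phenylethenyl on the shared core; compound 3 carries phenethyl but on a different core, so its value against that of compound 2 shows only that two things differ at once. The change removes the double bond outside aromatic rings and leaves the rest as it was. A modest downward step, or none beyond the scatter, is expected: a number 9 percentage points lower from compound 2 to compound 4 (within the scatter). Compound 4 is therefore estimated at 40%, with a range from 22% to 58%.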

Compound 4, a percentage reported as inhibition, at one concentration (the size of the read-out at that concentration, not a potency): 47%
Compound 4: the middle estimate sits 7 percentage points below what was measured; the range from low to high includes it.
By their numbers in this assay, from the lowest: compound 3; then compound 1; then compounds 4 and 2 (each within the scatter of the next).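

In this assay, phenethyl in place of 2-phenylethenyl on the shared core gives a number 2 percentage points lower from compound 2 to compound 4 (within the scatter), so at this position the double bond outside aromatic rings makes no difference that can be read. Phenethyl in place of phenoxy gives a number 17 percentage points higher from compound 1 to compound 4 (beyond the scatter), which shows that the rise over phenoxy does not depend on that double bond. Nothing available explains why these groups compare as they do.

Open, on these data alone, is whether the number holds with a shorter link, as in benzyl, or a longer chain, as in 3-phenylpropyl, at this aromatic carbon. Also open, as far as these compounds go, is what an amine or a carboxylic acid on the phenethyl group would do to the inhibition at the tested concentration.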